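The compounds below may be only part of what the source reports. "The series", "measured", "known", "first", "only" and "open" are said of these compounds alone.

Compound 1, with the structure `Oc1cccc2[nH]c(-c3ccc(-c4ccc(-c5ccc(F)cc5)cc4)cc3)nc12`, was tested in a functional assay on A2780 cells (Homo sapiens) for inhibition, read by sulforhodamine B assay (on this read-out higher numbers stand for weaker inhibition of growth and lower numbers for stronger inhibition of growth), and gives 41200 nM. Compound 2, with the structure `Oc1cccc2[nH]c(-c3ccc(-c4ccc(-c5ccc(C(F)(F)F)cc5)cc4)cc3)nc12`, differs from it in one place: trifluoromethyl in place of fluoro on an aromatic carbon. In this assay compound 2 gives 6100 nM, so the change brought a 6.8-fold lower number from compound 1 to compound 2 (0.83 log units; beyond the scatter).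

Compound 3, with the structure `Cc1ccc2[nH]c(-c3ccc(-c4ccc(-c5ccc(F)cc5)cc4)cc3)nc2c1`, carries a different core; the difference between the two cores is not broken down here. In this assay compound 3 gives 24600 nM, which stands close to the number of compound 1 and well apart from the number of compound 2.

Compound 4, with the structure `Cc1ccc2[nH]c(-c3ccc(-c4ccc(-c5ccc(C(F)(F)F)cc5)cc4)cc3)nc2c1`, has not yet been measured. It differs from compound 3 in one place: trifluoromethyl in place of fluoro on an aromatic carbon. This is the same change that led from compound 1 to compound 2, made on the same kind of position in both pairs. For the measured compounds named here, since it is the only change on the way to compound 4, and the change from compound 1 to compound 2 is the one comparable step on record, the expected size of the step is read from that pair. Compound 4 is expected to show a 6.6-fold lower number from compound 3 to compound 4 (0.82 log units; beyond the scatter) in this assay, because a 6.8-fold lower number from compound 1 to compound 2 (0.83 log units; beyond the scatter). Going by the values given here, the estimate for compound 4 in this assay is therefore 3700 nM, with a likely range from 1500 nM to 9000 nM; a wider range is allowed since only one earlier example of this change is available.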

Compound 4, concentration for 50% growth inhibition: 12300 nM
For compound 4 the middle estimate is 3.3-fold (0.52 log units) below the measured one, and the stated range ends below it.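

On the core of compound 3, trifluoromethyl in place of fluoro gave a 2.0-fold lower number from compound 3 to compound 4 (0.30 log units; within the scatter), so in this assay this pair cannot be told apart, although the same change separated the pair on the core of compound 1. The two trifluoromethyl compounds are not separated either, with 5-methyl-1H-benzimidazol-2-yl in place of 4-hydroxy-1H-benzimidazol-2-yl giving a 2.0-fold higher number from compound 2 to compound 4 (0.30 log units; within the scatter). The size of the step therefore did not carry over from one core to the other: the same change on two cores in this assay, a 6.8-fold lower number (0.83 log units; beyond the scatter) from compound 1 to compound 2 and a 2.0-fold lower number (0.30 log units; within the scatter) from compound 3 to compound 4, 3.4-fold (0.53 log units) apart, beyond the scatter of two such steps. For the compounds shown here, these two pairs show only that the step can depend on the core; they do not show which feature of the cores governs its size, or how the change would behave on any third core.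

The compounds shown leave open whether the gap between the two steps follows the hydroxy group, the methyl group or both, which a core carrying an amine or a methoxy group in their place could begin to test. They also leave open how other groups would read in the place of fluoro and trifluoromethyl, such as a nitrile, a carboxylic acid or a longer chain.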